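The compounds below may be only part of what the source reports. "The series", "measured", "known", "first", "only" and "open" are said of these compounds alone.

In an assay on isolated protein for binding affinity to 5-hydroxytryptamine receptor 1E (Homo sapiens) (a higher number here means a weaker inhibitor, a lower number a stronger inhibitor), three close relatives of compound 4 have been measured, and none has given a number. Compound 1 `Cc1cccc(-c2n[nH]cc2N2CCCNCC2)c1` gives > 10000 nM in this assay, which is a limit of the assay and not a number. Compound 2 `Cc1ccc(-c2n[nH]cc2N2CCCNCC2)cc1` likewise gives > 10000 nM in this assay, again a limit. Compound 3 `Fc1ccc(-c2n[nH]cc2N2CCCNCC2)cc1` gives > 10000 nM in this assay, also a limit. Among the measured compounds shown here, the only single-point step among the measured compounds is the one recorded as a step that the two limits leave unreadable from compound 2 to compound 3, and its size is unreadable since both ends are limits. Where compound 3 stands on these numbers is thus known only as a limit, and the two further values shown are limits as well; the one piece of evidence bearing on the measured step is the limit of > 10000 nM in this assay, at which 3 of the 3 values shown sit.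

Compound 4 `c1ccc(-c2n[nH]cc2N2CCCNCC2)cc1` differs from compound 3 by hydrogen in place of fluoro on an aromatic carbon. For the measured compounds named here, no measured step tells how large a change this brings in this assay or in which direction, so the expectation rests on the three limits alone. Compound 4 is therefore expected to stay at or beyond the limit, with a step that the limit leaves unreadable from compound 3 to compound 4 from compound 3, which is no step beyond the scatter. The estimate for compound 4 in this assay is 20000 nM, in the range 8000 nM to 60000 nM.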

Compound 4, inhibition constant: > 10000 nM
Compound 4 ended at the assay's limit; the forecaster's own chance of this, stated with the estimate: 85%; the middle value does not contradict the limit.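

In this assay compound 4 gives > 10000 nM as a limit of the assay and not a number. No new step can be read between compound 4 and compound 1, compound 2 or compound 3, as every value is a limit: the limit of > 10000 nM in this assay, at which 4 of the 4 values shown sit. The compounds shown leave open how far past the limit each lies in this assay and whether hydrogen, fluoro or methyl on the aromatic carbon makes any difference.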